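Chloro for fluoro: cytotoxicity across two amide cores

The source may report more compounds than this note shows. Statements on the series, on what has been measured and on what is new or still open speak of the compounds shown alone.

Three compounds have been run in an ADME assay on RAW264.7 cells (Mus musculus) for cytotoxicity, read by MTT assay, with a stated time of 24 h; a lower number here means that less compound is tolerated, a higher number that more compound is tolerated. Compound 1 `COc1ccc(C(=O)Nc2ccc(Cl)cc2F)c(OCc2ccc(F)cc2F)c1` gives > 40000 nM in this assay, which is a limit of the assay and not a number. Compound 2 `COc1ccc(C(=O)Nc2ccc(F)cc2F)c(OCc2ccc(F)cc2F)c1` likewise gives > 40000 nM in this assay, again a limit rather than a number. Compound 1 differs from compound 2 by chloro in place of fluoro on an aromatic carbon. The step that the two limits leave unreadable from compound 2 to compound 1 cannot be read because of the limit of > 40000 nM in this assay, at which 2 of the 3 values shown sit, so the size of this change on the first core is not known from these two compounds.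

Within the data shown here, compound 3 `O=C(Nc1ccc(-c2ccc(F)cc2F)cc1F)c1ccccc1O` is the one compound with a measured number here: in this assay compound 3 gives 28600 nM. How the core of compound 3 differs from the core of compound 2 is not broken down here.

Compound 4 `O=C(Nc1ccc(-c2ccc(Cl)cc2F)cc1F)c1ccccc1O` has not yet been measured in this assay. It differs from compound 3 by chloro in place of fluoro on an aromatic carbon, the same change that leads from compound 2 to compound 1, and at a place described in the same words for both pairs. Since the step from compound 2 to compound 1 is unreadable, the expectation for compound 4 rests on the value of compound 3, 28600 nM, and on the usual scatter of this kind of measurement. The step from compound 3 to compound 4 is expected to be small, about a 1.0-fold higher number from compound 3 to compound 4 (0.02 log units; within the scatter). Compound 4 is accordingly estimated at 30000 nM in this assay, with a likely range from 14000 nM to 60000 nM.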

Compound 4, half-maximal cytotoxic concentration: 27200 nM
For compound 4 the middle estimate is 1.1-fold (0.04 log units) above the measured one; the range from low to high includes it.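

In this assay the change of chloro in place of fluoro, here 2,4-difluorophenyl to 4-chloro-2-fluorophenyl, is a 1.1-fold lower number from compound 3 to compound 4 (0.02 log units; within the scatter), so the two members of this pair cannot be told apart on this core. On the core of compound 1 the same change cannot be read, since compound 1 and compound 2 both carry a limit of the assay and not a number: the limit of > 40000 nM in this assay, at which 2 of the 4 values shown sit. The series therefore offers one readable pair on one core, which shows that the change made no visible difference there but does not show that this result carries over from one core to the other, and no size can be compared between the two cores.

Open, going by these compounds, is whether the same silence in this assay holds when the chloro on the core of compound 3 gives way to a group of a different kind, such as an amine or a carboxylic acid, or when the change is made elsewhere on that ring. Also open, on these data alone, is whether compound 1 and compound 2 differ from each other at all, and so whether the two cores respond alike to this change.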